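A longer sulfone chain in place of the sulfoxide arm

The compounds below may be only part of what the source reports. "The series", "measured", "known", "first", "only" and "open" are said of these compounds alone.

In a functional assay on the whole organism with Rattus norvegicus as the target (on this read-out lower numbers stand for an effect already at smaller amounts and higher numbers for an effect only at larger amounts of compound), compound 1 `Cn1c(=N)sc2cc(OC(F)(F)F)ccc21` gives 5 mg/kg. Compound 2 `C[S+]([O-])CCn1c(=N)sc2cc(OC(F)(F)F)ccc21` gives 1.1 mg/kg, the lowest of the two numbers, after the step of a 4.5-fold lower number from compound 1 to compound 2 (0.66 log units; beyond the scatter). Compound 3 `CS(=O)(=O)CCCn1c(=N)sc2cc(OC(F)(F)F)ccc21` differs from compound 2 by a group of 5 heavy atoms (2 carbon, 2 oxygen, 1 sulfur; no ring) in place of a group of 3 heavy atoms (1 carbon, 1 oxygen, 1 sulfur; no ring), on a saturated chain carbon, two bonds along the chain from an aromatic nitrogen. Among the compounds with values here, only the step of a 4.5-fold lower number from compound 1 to compound 2 (0.66 log units; beyond the scatter) bears on this change, and it shows that a chain bearing sulfur and oxygen on the aromatic nitrogen lowered the number; exchanging one such chain for another is expected to move the number little, within the scatter. Compound 3 is therefore expected to give about 1.2 mg/kg, between 0.4 mg/kg and 3.5 mg/kg. This estimate means an expected step of a 1.1-fold higher number from compound 2 to compound 3 (0.04 log units; within the scatter).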

Compound 3, dose for half-maximal effect: 5 mg/kg
Estimate against measurement, compound 3: 4.2-fold (0.62 log units) below; measured number outside the range, above it.
By their numbers in this assay, from the lowest: compound 2; then compounds 1 and 3 (each within the scatter of the next).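

In this assay, replacing the sulfoxide end of the chain with (methylsulfonyl)methyl gave a 4.5-fold higher number from compound 2 to compound 3 (0.66 log units; beyond the scatter), so exchanging one such chain for another is not neutral at this place. With no change at the digits printed from compound 1 to compound 3 (within the scatter), the 2-(methylsulfonyl)ethyl arm keeps none of the gain seen with compound 2, and a chain bearing sulfur and oxygen does not by itself lower the number. Nothing measured here bears on why the number moved. Compound 3 alters both the sulfur group and the chain length, and the compounds shown do not separate the two. From the compounds shown here alone, a methylsulfonyl group on a chain the length of that in compound 2 remains open, as does an amine or a carboxylic acid in this place.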